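Permeability of the carbamate analogue in the bicyclic amide series

A few compounds are considered here, and "the series" means these few. Any claim that something is new, unique, unknown or untested is made for them only; others in the source may bear on it.

Of the compounds shown here, three sharing one core have been measured in an ADME assay on Caco-2 cells (Homo sapiens) for permeability, in the apical to basolateral direction, with a stated time of 90 min, tested at 10 uM; on this read-out higher numbers stand for higher permeability and lower numbers for lower permeability. Compound 1 `O=C(NC[C@@H]1[C@H]2CN(C(=O)CCc3cc(Cl)cc(Cl)c3)C[C@@H]12)c1ccc2[nH]c(=O)oc2c1` gives 18 10^-6 cm/s. Compound 2 `O=C(NC[C@@H]1[C@H]2CN(C(=O)C3CC3c3cc(Cl)cc(Cl)c3)C[C@@H]12)c1ccc2[nH]c(=O)oc2c1` gives 64 10^-6 cm/s, and compound 3 `O=C(NC[C@@H]1[C@H]2CN(C(=O)NCc3cc(Cl)cc(Cl)c3)C[C@@H]12)c1ccc2[nH]c(=O)oc2c1` gives 2 10^-6 cm/s, the lowest of the three numbers. Among the measured steps, a 3.6-fold higher number from compound 1 to compound 2 (0.55 log units; beyond the scatter), a 9.0-fold lower number from compound 1 to compound 3 (0.95 log units; beyond the scatter) and a 32-fold lower number from compound 2 to compound 3 (1.51 log units; beyond the scatter), so compound 3 sits clearly beneath both neighbours in this assay.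

Compound 4 `Cc1ccc(COC(=O)N2C[C@@H]3[C@@H](CNC(=O)c4ccc5[nH]c(=O)oc5c4)[C@@H]3C2)nc1` is the next analogue: a group of 9 heavy atoms (7 carbon, 1 nitrogen, 1 oxygen; one six-membered aromatic ring with 1 hetero atom) in place of a group of 10 heavy atoms (7 carbon, 1 nitrogen, 2 chlorine; one six-membered aromatic ring of carbon only), on a carbonyl carbon. The leaving group carries one hydrogen-bond donor and no acceptor; the entering group carries no donor and two acceptors.

Going by the values given here, no measured step repeats this exact change, so the steps bear on it only loosely. Both changes away from compound 3 toward the amides, compound 1 and compound 2, gave higher numbers, so the direction from the urea of compound 3 to the carbamate of compound 4 is expected to be upward, of modest size rather than the largest seen. The estimate for compound 4 is 10 10^-6 cm/s in this assay, with a range from 3 10^-6 cm/s to 30 10^-6 cm/s, meaning an expected step of a 5.0-fold higher number from compound 3 to compound 4 (0.70 log units; beyond the scatter).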

Compound 4, apparent permeability: 1 10^-6 cm/s
Compound 4: middle estimate off by 10-fold (1.00 log units), on the high side; the measured number lies below the stated range.
By their numbers in this assay, from the lowest: compounds 4 and 3 (each within the scatter of the next); then compound 1; then compound 2.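

In this assay, placing the carbamate group on a carbonyl carbon whose other neighbours are an amide-type nitrogen in a ring, in place of (3,5-dichlorobenzyl)amino, gives a 2.0-fold lower number from compound 3 to compound 4 (0.30 log units; within the scatter), so compound 3 and compound 4 cannot be told apart on this read-out even though the entering group carries no hydrogen-bond donor and the leaving group carries one. Compound 4 also stands well under both amides, with an 18-fold lower number from compound 1 to compound 4 (1.26 log units; beyond the scatter) and a 64-fold lower number from compound 2 to compound 4 (1.81 log units; beyond the scatter), so among these four compounds the two with a heteroatom joining the side chain to the carbonyl carbon give the lowest numbers, and no compound shown goes against this. Nothing at hand gives a reason for these numbers.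

Compound 4 differs from compound 3 in both the linking atom and the aromatic ring, so the contribution of each remains unresolved. A (3,5-dichlorobenzyl)oxy group or a 2-(pyridinyl)ethyl group on the same carbonyl carbon would separate the linking atom from the ring, and the compounds shown leave open which of the two tracks with the numbers.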